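The compounds below may be only part of what the source reports. "The series", "measured", "known", "first", "only" and "open" are said of these compounds alone.

In a functional assay on THP-1 cells (Homo sapiens) for cytotoxicity, read by MTT assay, with a stated time of 24 h (a higher number here means a weaker inhibitor, a lower number a stronger inhibitor), compound 3 `COc1cc(/C=C2\CN(C)C/C(=C\c3ccc(Cl)cc3Cl)C2=O)cc(OC)c1OC` has the highest number of the three measured compounds, at 5020 nM. Compound 1 `COc1cc(/C=C2\CN(C)C/C(=C\c3cccc([N+](=O)[O-])c3)C2=O)cc(OC)c1` gives 1770 nM and compound 2 `COc1cc(/C=C2\CN(C)C/C(=C\c3cc(OC)c(OC)c(OC)c3)C2=O)cc(OC)c1` gives 720 nM. Unmeasured compound 4 `COc1cc(/C=C2\CN(C)C/C(=C\c3cccc([N+](=O)[O-])c3)C2=O)cc(OC)c1OC` departs from compound 3 by a single change, 3-nitrophenyl in place of 2,4-dichlorophenyl on a double-bonded chain carbon bound to a double-bonded ring carbon.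

Among the compounds with values here, no measured step makes this exact exchange. The closest evidence is a 7.0-fold higher number from compound 2 to compound 3 (0.84 log units; beyond the scatter), a modest step in which arrival of the 2,4-dichlorophenyl goes with a higher number. The number of compound 3 is higher than that of compound 1, which carries the 3-nitrophenyl and gives 1770 nM, although these two also differ elsewhere, so compound 1 gives only indirect support. Within the data shown here, a step smaller than the one to compound 3 from compound 2 is therefore expected, toward a lower number in this assay. The expected move is a 2.8-fold lower number from compound 3 to compound 4 (0.45 log units; beyond the scatter). The estimated value for compound 4 is 1800 nM, with an expected range of 750 nM to 4000 nM.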

Compound 4, half-maximal inhibitory concentration: 890 nM
Beside the measured number, compound 4's estimate is 2.0-fold (0.31 log units) above it, and the stated range covers the measured number.
By their numbers in this assay, from the lowest: compounds 2, 4 and 1 (each within the scatter of the next, the first and the last beyond it); then compound 3.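

In this assay, the exchange at this position now has a direct reading: 3-nitrophenyl in place of 2,4-dichlorophenyl gives a 5.6-fold lower number from compound 3 to compound 4 (0.75 log units; beyond the scatter), so the high number of compound 3 goes with the 2,4-dichlorophenyl while the rest of the structure stays the same. With 3-nitrophenyl in place of 3,5-dimethoxyphenyl, the result is a 1.2-fold higher number from compound 2 to compound 4 (0.09 log units; within the scatter), so these two groups are not separated at this position, whereas the 2,4-dichlorophenyl stands apart from both. Methoxy in place of hydrogen on an aromatic carbon gives a 2.0-fold lower number from compound 1 to compound 4 (0.30 log units; within the scatter), so that change is not resolved here.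

As far as these compounds go, whether a phenyl carrying an amine or a carboxylic acid at this place would track the 2,4-dichlorophenyl or the 3-nitrophenyl stays open. Nothing available bears on why the 2,4-dichlorophenyl stands apart.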